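Replacing tert-butyl with phenyl: how large a step?

The source may hold more compounds than are shown below. What is called first, only, known or untested is meant among the compounds shown, and "the series" means these compounds.

Compound 1 `N#Cc1ccc(Cn2ccc3nc(-c4ccccc4)nc-3c2)cc1`: > 100000 nM (a limit of the assay, not a number)
Compound 2 `CC(C)(C)c1ccc(Cn2ccc3nc(-c4ccccc4)nc-3c2)cc1`: 22000 nM

Among the compounds with values here, in an ADME assay on MDBK cells (Bos taurus) for cytotoxicity (on this read-out lower numbers stand for higher toxicity in this test and higher numbers for lower toxicity in this test), compound 2, at 22000 nM, holds the only exact number so far. Compound 1 gives only a limit, > 100000 nM.

Compound 3 `c1ccc(-c2ccc(Cn3ccc4nc(-c5ccccc5)nc-4c3)cc2)cc1` differs from compound 2 by one change, phenyl in place of tert-butyl on an aromatic carbon, para to a large group.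

Within the data shown here, only one measured step bears on this: an at least 4.5-fold lower number from compound 1 to compound 2 (0.65 log units; beyond the scatter), which came with tert-butyl in place of cyano. Leaving that step aside, the new change swaps one carbon-only group for another, so no step beyond the scatter is expected in this assay, and the direction stays open. The expected step is a 1.1-fold lower number from compound 2 to compound 3 (0.04 log units; within the scatter). For compound 3 the estimate is 20000 nM, with an expected range from 7000 nM to 60000 nM.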

Compound 3, half-maximal cytotoxic concentration: 18000 nM
For compound 3 the middle estimate is 1.1-fold (0.05 log units) above the measured one; measured number inside the range.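

In this assay, phenyl in place of tert-butyl on this aromatic carbon gives a 1.2-fold lower number from compound 2 to compound 3 (0.09 log units; within the scatter), so a carbon-only group with a ring and one without cannot be told apart at this position. Phenyl in place of the nitrile gives an at least 5.5-fold lower number from compound 1 to compound 3 (0.74 log units; beyond the scatter), which runs in the same direction as an at least 4.5-fold lower number from compound 1 to compound 2 (0.65 log units; beyond the scatter), so both carbon-only groups now stand on the lower side of the nitrile. Compound 1 gives only a limit, so both steps from it have an open end: the limit of > 100000 nM in this assay, at which 1 of the 3 values shown sits.

Three groups at one position cannot show whether the lower numbers go with carbon-only groups in general. An amine or a carboxylic acid on this aromatic carbon would test whether a group holding nitrogen or oxygen stays on the nitrile's side.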